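Aryl variation on the triazole nitrogen: cytotoxicity notes

The source may report more compounds than this note shows. Statements on the series, on what has been measured and on what is new or still open speak of the compounds shown alone.

Compound 1 `CC1(C)[C@H]2CC[C@]1(C)N(Cc1cn(-c3ccc(C#N)cc3)nn1)C(=O)C2` is the reference point of the series. In an ADME assay on NCM460 cells (Homo sapiens) for cytotoxicity, read by MTT assay, with a stated time of 24 h (a higher number here means that more compound is tolerated, a lower number that less compound is tolerated), compound 1 gives 8140 nM, the lowest of the three numbers recorded so far. Compound 2 `CC1(C)[C@H]2CC[C@]1(C)N(Cc1cn(-c3cccc(Cl)c3)nn1)C(=O)C2` gives 8410 nM in this assay; the step of a 1.0-fold higher number from compound 1 to compound 2 (0.01 log units; within the scatter) shows that exchanging one aryl group on the triazole nitrogen for another leaves the number essentially where it was. Compound 3 `CC1(C)[C@H]2CC[C@]1(C)N(Cc1cn(-c3ccccc3)nn1)C(=O)C2` gives 19600 nM in this assay; here the steps of a 2.4-fold higher number from compound 1 to compound 3 (0.38 log units; beyond the scatter) and a 2.3-fold higher number from compound 2 to compound 3 (0.37 log units; beyond the scatter) are both modest and run the same way.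

Compound 4 `CC1(C)[C@H]2CC[C@]1(C)N(Cc1cn(-c3cccc(Br)c3)nn1)C(=O)C2` has not yet been measured in this assay. Its change from compound 1 is 3-bromophenyl in place of 4-cyanophenyl on an aromatic nitrogen. The step that bears most directly on it is a 1.0-fold higher number from compound 1 to compound 2 (0.01 log units; within the scatter), in which one substituted aryl group was replaced by another on the same ring nitrogen and nothing beyond the scatter appeared. Compound 4 carries a 3-bromophenyl group, a close relative of the 3-chlorophenyl of compound 2, so the expectation in this assay is for no step beyond the scatter. The estimate for compound 4 is 8500 nM, with a range from 4200 nM to 17000 nM. The expected step from compound 1 is therefore a 1.0-fold higher number from compound 1 to compound 4 (0.02 log units; within the scatter).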

Compound 4, half-maximal cytotoxic concentration: 14600 nM
The estimate for compound 4 lay 1.7-fold (0.23 log units) below the measured number; the measured number falls inside the stated range.
By their numbers in this assay, from the lowest: compounds 1, 2, 4 and 3 (each within the scatter of the next, the first and the last beyond it).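

In this assay the 3-bromophenyl group cannot be told apart from any aryl group seen earlier at this ring nitrogen, since a 1.8-fold higher number from compound 1 to compound 4 (0.25 log units; within the scatter) and a 1.7-fold higher number from compound 2 to compound 4 (0.24 log units; within the scatter) and a 1.3-fold lower number from compound 3 to compound 4 (0.13 log units; within the scatter) are all printed as within the scatter. The earlier series had suggested a clean split, with the unsubstituted phenyl of compound 3 standing apart from the substituted aryl groups of compound 1 and compound 2, but compound 4 carries a substituent and goes against that split, so a substituent on the aryl ring does not by itself mark a compound as separate from compound 3. Exchanging chloro for bromo is the smallest change tried at this aryl ring, and it already leaves compound 4 linked by steps within the scatter to two compounds that are themselves beyond the scatter of each other. Nothing available here bears on why the steps fall as they do.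

Open, going by these compounds, is whether a 4-bromophenyl group would behave like the 3-bromophenyl of compound 4, which would separate the effect of the substituent's place from that of its identity. Also open, on these data alone, is whether an amine or a carboxylic acid on the aryl ring, or a longer chain in place of the aryl group, would give a step beyond the scatter from compound 3.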